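A few compounds are considered here, and "the series" means these few. Any claim that something is new, unique, unknown or untested is made for them only; others in the source may bear on it.

Of the compounds shown here, three sharing one core have been measured in a functional assay on HCT-116 cells (Homo sapiens) for antiproliferative activity, read by MTT assay, with a stated time of 48 h; a higher number here means a weaker inhibitor, a lower number a stronger inhibitor. Compound 1 (`CCCCCC(CCO)n1cnc2c(Cl)nc(Cl)nc21`) gives 6170 nM. Compound 2 (`CCCCCC(CCO)n1cnc2c(NC)ncnc21`) reaches only a limit, > 50000 nM. Compound 3 (`CCCCCC(CCO)n1cnc2c(N)ncnc21`) also reaches only a limit, > 50000 nM. This places compound 3 at the limit of > 50000 nM in this assay, at which 2 of the 3 values shown sit, so it has no number of its own from which to count.

Compound 4 (`CCCCCC(CCO)n1cnc2c(N)nc(Cl)nc21`) arises from compound 3 through a single change, chloro in place of hydrogen on an aromatic carbon, between two ring nitrogen atoms: chloro in place of hydrogen on an aromatic carbon.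

Among the compounds with values here, the only measured step, a step that the two limits leave unreadable from compound 2 to compound 3, offers no size to carry over, and it concerns a nitrogen rather than this carbon. Within the data shown here, the closest guide is compound 1, which carries chloro on the same carbon and gives 6170 nM, the only number among the three. On that basis, compound 4 is expected to be a stronger inhibitor than compound 3 in this assay, though it may well stay close to the limit. The expected change is an at least 2.5-fold lower number from compound 3 to compound 4 (0.39 log units; beyond the scatter), and its size is loose. For compound 4 the estimate is 20000 nM, with an expected range from 7000 nM to 50000 nM.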

Compound 4, half-maximal inhibitory concentration: > 50000 nM
Compound 4 ended at the assay's limit; the forecaster's own chance of this, stated with the estimate: 35%; middle value at least 2.5-fold (0.39 log units) from the limit.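

In this assay, chloro on the aromatic carbon between two ring nitrogen atoms is not enough on its own to give a measurable value when the amino group is present, and compound 4 gives only a limit, like compound 2 and compound 3: the limit of > 50000 nM in this assay, at which 3 of the 4 values shown sit. The step from compound 3 to compound 4 and the step from compound 2 to compound 3 cannot be read, so any effect of this chloro in the presence of the amino group remains hidden behind the limit. The readable comparison is with compound 1: with the chloro between two ring nitrogen atoms common to both compounds, amino in place of the other chloro gives an at least 8.1-fold higher number from compound 1 to compound 4 (0.90 log units; beyond the scatter), so in this assay that second carbon matters even with the first chloro in place.

Going by these compounds, whether a methoxy group, a thiol or a larger amine on that second carbon would bring a compound back under the limit stays open. So does whether a shorter chain on the shared core would change the value of compound 1.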